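One Methoxy Fewer: Expecting the Next Cytotoxicity Number

The compounds below may be only part of what the source reports. "The series", "measured", "known", "first", "only" and "open" are said of these compounds alone.

Compound 1, `COc1ccc(/C=C/C(=O)c2ccccc2F)c(OC)c1`: 87.3 nM
Compound 2, `COc1cc(OC)c(OC)cc1/C=C/C(=O)c1ccccc1F`: 79 nM

Compound 2 holds the lower of the two numbers in a functional assay on A549 cells (Homo sapiens) for cytotoxicity, read by MTT assay, with a stated time of 72 h (a higher number here means a weaker inhibitor, a lower number a stronger inhibitor), yet the step of a 1.1-fold lower number from compound 1 to compound 2 (0.04 log units; within the scatter) is within the scatter, so the two stand level. Compound 3, `COc1ccc(OC)c(/C=C/C(=O)c2ccccc2F)c1`, differs from compound 2 by hydrogen in place of methoxy on an aromatic carbon. Among the measured compounds shown here, the only measured step that bears on this, a 1.1-fold lower number from compound 1 to compound 2 (0.04 log units; within the scatter), concerns a methoxy at a different aromatic carbon and was within the scatter. No step beyond the scatter is therefore expected; the estimated change in this assay is a 1.3-fold higher number from compound 2 to compound 3 (0.10 log units; within the scatter). In this assay compound 3 is expected to give about 100 nM, in the range 40 nM to 250 nM.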

Compound 3, half-maximal inhibitory concentration: 114 nM
Beside the measured number, compound 3's estimate is 1.1-fold (0.06 log units) below it, and the stated range covers the measured number.
By their numbers in this assay, from the lowest: compounds 2, 1 and 3 (each within the scatter of the next).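

In this assay, exchanging the methoxy para to a large group for hydrogen gives a 1.4-fold higher number from compound 2 to compound 3 (0.16 log units; within the scatter), so the two stand level. This extends the earlier finding to a second aromatic carbon: the methoxy at this position, ortho to one methoxy group and meta to another, can go without a step beyond the scatter. No available evidence accounts for this result. The compounds shown leave open whether an amine, a carboxylic acid or a longer alkoxy chain at this same carbon would give a step beyond the scatter.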